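A few compounds are considered here, and "the series" means these few. Any claim that something is new, unique, unknown or untested is made for them only; others in the source may bear on it.

For the measured compounds named here, in a functional assay on G-361 cells (Homo sapiens) for inhibition, with a stated time of 72 h (on this read-out lower numbers stand for stronger inhibition and higher numbers for weaker inhibition), compound 2 `OC1CCC(Nc2nc(NCc3ccc(-c4ccco4)nc3)c3ncn(C4CCCC4)c3n2)CC1` gives 443 nM and holds the lower of the two numbers so far. Compound 1 `CC(C)(O)CNc1nc(NCc2ccc(-c3ccco3)cc2)c2ncn(C3CCCC3)c2n1` stands at 17400 nM on this read-out, a gap well beyond the scatter. The next structure is compound 3 `CC(C)(O)CNc1nc(NCc2ccc(-c3ccco3)nc2)c2ncn(C3CCCC3)c2n1`, and the change from compound 2 reads 2-hydroxy-2-methylpropyl in place of 4-hydroxycyclohexyl on a nitrogen on an aromatic ring with 2-hydroxy-2-methylpropyl in place of 4-hydroxycyclohexyl on a nitrogen on an aromatic ring. Going by the values given here, no step between measured compounds shows this change on its own. Compound 1 also carries 2-hydroxy-2-methylpropyl and gives 17400 nM in this assay so a weaker number is expected for compound 3, beyond the scatter. The expected step is a 5.6-fold higher number from compound 2 to compound 3 (0.75 log units; beyond the scatter) and remains an estimate. The estimated value for compound 3 is 2500 nM with an expected range of (700 nM to 9000 nM).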

Compound 3, half-maximal inhibitory concentration: 2100 nM
The estimate for compound 3 lay 1.2-fold (0.08 log units) above the measured number; measured number inside the range.
By their numbers in this assay, from the lowest: compound 2; then compound 3; then compound 1.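

In this assay the substituent on the amino nitrogen can now be read on its own: with the 6-(furan-2-yl)pyridin-3-yl group held constant, 2-hydroxy-2-methylpropyl in place of 4-hydroxycyclohexyl gives a 4.7-fold higher number from compound 2 to compound 3 (0.68 log units; beyond the scatter) and places the open chain on the weaker side. The aryl group can also be read on its own: with 2-hydroxy-2-methylpropyl held constant, 6-(furan-2-yl)pyridin-3-yl in place of 4-(furan-2-yl)phenyl gives an 8.3-fold lower number from compound 1 to compound 3 (0.92 log units; beyond the scatter) in favour of the pyridine-bearing compound. Nothing at hand bears on the cause of either step.

As far as these compounds go, whether the hydroxycyclohexyl advantage carries over to the 4-(furan-2-yl)phenyl compounds remains open, since the two steps share only compound 3. Also open, from the compounds shown here alone, is how a primary amine in place of the hydroxyl, or a longer hydroxyalkyl chain, would read at this nitrogen.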